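The source may hold more compounds than are shown below. What is called first, only, known or untested is meant among the compounds shown, and "the series" means these compounds.

Compound 1 `Cc1ccc(-c2nc(N)c3cc(Cc4ccccc4)sc3n2)o1` gives 298 nM in a functional assay on CHO-K1 cells for antagonist activity at adenosine receptor A1 (Homo sapiens), read by a beta-galactosidase reporter and cAMP accumulation, with stated times of 15 min and 6 h; on this read-out lower numbers stand for stronger inhibition and higher numbers for weaker inhibition. Compound 2 `Nc1nc(-c2ccncc2)nc2sc(Cc3ccccc3)cc12` gives 812 nM in this assay.

Among the compounds with values here, of the two numbers in this assay, compound 2 stands highest; the only measured step, a 2.7-fold higher number from compound 1 to compound 2 (0.44 log units; beyond the scatter), lies beyond the scatter. Compound 3 `Nc1nc(-c2cnccn2)nc2sc(Cc3ccccc3)cc12` differs from compound 2 in one place: pyrazin-2-yl in place of pyridin-4-yl on an aromatic carbon. Within the data shown here, no measured step exchanges a pyridin-4-yl for a pyrazin-2-yl; the one step known here exchanges a different ring and shows only the size such ring swaps have reached. The step to compound 3 is therefore expected to stay within the scatter, a 1.1-fold higher number from compound 2 to compound 3 (0.04 log units; within the scatter). Compound 3 is estimated at 900 nM, between 350 nM and 2500 nM.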

Compound 3, inhibition constant: 91 nM
Compound 3: middle estimate off by 9.9-fold (1.00 log units), on the high side, outside the stated range (below it).
By their numbers in this assay, from the lowest: compound 3; then compound 1; then compound 2.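

At this position, the identity of the six-membered ring decides the direction of the step. The change from pyridin-4-yl to pyrazin-2-yl gives an 8.9-fold lower number from compound 2 to compound 3 (0.95 log units; beyond the scatter) in this assay, so moving the ring nitrogen and adding a second one, with the heavy-atom count unchanged, is not a neutral swap. Replacing 5-methylfuran-2-yl with a six-membered ring need not raise the number either, as pyrazin-2-yl gives a 3.3-fold lower number from compound 1 to compound 3 (0.52 log units; beyond the scatter).

Nothing available explains these differences. From the compounds shown here alone, how a phenyl or pyrimidin-2-yl ring, or an open-chain amine, would compare here remains open.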